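The source may report more compounds than this note shows. Statements on the series, on what has been measured and on what is new or still open speak of the compounds shown alone.

Compound 1 `CCCc1nn(C)c2c(N3CCC(O)CC3)nc(/C=C/c3cc(OC)c(OC)c(OC)c3)nc12` - 13700 nM
Compound 2 `CCCc1nn(C)c2c(Nc3ccccc3)nc(/C=C/c3ccccc3)nc12` - "not active" (no number reported)

Among the measured compounds shown here, in a functional assay on RAW264.7 cells (Mus musculus) for inhibition, read by Griess assay, with stated times of 1 h and 24 h (a higher number here means a weaker inhibitor, a lower number a stronger inhibitor), compound 1 gives 13700 nM, the only number available so far. Compound 2 is reported as "not active" (no number reported) and carries no number, so it cannot be placed on a scale with compound 1. It also differs from compound 1 in more than one place.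

Compound 3 `CCCc1nn(C)c2c(NC(C)C)nc(/C=C/c3cc(OC)c(OC)c(OC)c3)nc12` keeps the rest of compound 1 and changes a single place, with isopropylamino in place of 4-hydroxypiperidin-1-yl on an aromatic carbon. For the measured compounds named here, no two measured compounds differ in only one place, so the data do not size this change directly, and its direction in this assay remains open. With nothing to favour either direction, the expectation stays anchored on compound 1 at 13700 nM, and no step beyond the scatter is expected. The estimated step is a 1.1-fold lower number from compound 1 to compound 3 (0.06 log units; within the scatter). A report without a number, as for compound 2, also remains possible. For compound 3 the estimated value is 12000 nM, with an expected range from 4000 nM to 35000 nM.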

Compound 3, half-maximal inhibitory concentration: 3170 nM
Estimate against measurement, compound 3: 3.8-fold (0.58 log units) above; the whole stated range lies above it.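

Among the compounds shown here, compound 3 gives the first step that can be read at this position: in this assay, isopropylamino in place of 4-hydroxypiperidin-1-yl on the aromatic carbon next to the ring nitrogen gives a 4.3-fold lower number from compound 1 to compound 3 (0.64 log units; beyond the scatter) on an otherwise unchanged structure. The position is therefore not indifferent to what it carries, and the open-chain isopropylamino group, with no ring and fewer heavy atoms, gives the lower number of the pair. Nothing shown here gives a measured reason for this step.

This single step changes several things at once, losing the ring, the hydroxyl oxygen and part of the heavy-atom count together, so the compounds shown cannot say which of these differences goes with the lower number. Going by these compounds, a plain piperidin-1-yl group would separate the hydroxyl from the ring, while a cyclopentylamino group or a longer chain such as n-butylamino on the same carbon would show how the step depends on the size and shape of the group, and whether the trend continues remains open.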